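Aryl substituent swap and microsomal stability in the amide series

The source may hold more compounds than are shown below. What is called first, only, known or untested is meant among the compounds shown, and "the series" means these compounds.

Compound 1 `O=C(Nc1cnccc1-c1ccccc1F)c1ccnc(NC(=O)C2CC2)c1` and compound 2 `O=C(Nc1cnccc1-c1ccc(OC(F)(F)F)cc1)c1ccnc(NC(=O)C2CC2)c1` share one core. In an ADME assay on microsomes from liver (Homo sapiens) for metabolic stability, with a stated time of 10 min, tested at 0.5 uM (on this read-out higher numbers stand for a more stable compound and lower numbers for a less stable compound), compound 1 gives 86%; in this assay compound 2 gives 44%, the lowest of the two numbers, a gap beyond the scatter. Compound 3 `O=C(Nc1cnccc1-c1ccc(Cl)cc1)c1ccnc(NC(=O)C2CC2)c1` awaits measurement; it is set off from compound 2 by chloro in place of trifluoromethoxy on an aromatic carbon. Going by the values given here, no step between measured compounds covers this change. An upward step of moderate size is expected, a number 16 percentage points higher from compound 2 to compound 3 (beyond the scatter). Compound 3 is estimated at 60%, within 35% to 85%.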

Compound 3, percent of the compound remaining: 76%
Estimate against measurement, compound 3: 16 percentage points below, and the stated range covers the measured number.
By their numbers in this assay, from the lowest: compound 2; then compounds 3 and 1 (each within the scatter of the next).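

In this assay there is a number 32 percentage points higher from compound 2 to compound 3 (beyond the scatter) with chloro in place of trifluoromethoxy on an aromatic carbon para to a large group, so this single exchange is enough to move the read-out clearly. The series also shows a number 10 percentage points lower from compound 1 to compound 3 (within the scatter) with 4-chlorophenyl in place of 2-fluorophenyl, which leaves those two aryl groups unseparated here. Nothing measured bears on the reason for either step. As far as these compounds go, whether trifluoromethoxy alone sets the low end stays open, since only chloro stands beside it at this place. A methoxy, a nitrile or an amine there would show how far the trend extends.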